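Replacing the imidazolyl group of compound 2 with furan

The source may report more compounds than this note shows. Statements on the series, on what has been measured and on what is new or still open speak of the compounds shown alone.

Measured so far in a functional assay on A-375 cells (Homo sapiens) for antiproliferative activity; a higher number here means a weaker inhibitor, a lower number a stronger inhibitor:
- compound 1 `O=C(Nc1ccc(-c2cscn2)cc1)C1CCCN(Cc2ccc(F)c(F)c2)C1`: 880 nM
- compound 2 `O=C(Nc1ccc(-c2ncc[nH]2)cc1)C1CCCN(Cc2ccc(F)c(F)c2)C1`: 19000 nM

Of these two, compound 2, at 19000 nM, has the higher number and is the weaker inhibitor. Compound 3 `O=C(Nc1ccc(-c2ccco2)cc1)C1CCCN(Cc2ccc(F)c(F)c2)C1` keeps the shared core and changes at one place: furan-2-yl in place of 1H-imidazol-2-yl on an aromatic carbon. Going by the values given here, only one measured step bears on this place: a 22-fold higher number from compound 1 to compound 2 (1.33 log units; beyond the scatter). That step was large, and the 1H-imidazol-2-yl group stood on its weak side. Among the compounds with values here, no compound carrying furan-2-yl has been measured, so the transfer from that step is uncertain. Compound 3 loses the 1H-imidazol-2-yl group, so a sizeable fall in the number is expected, though not necessarily all the way to compound 1 at 880 nM. The estimated change is a 9.5-fold lower number from compound 2 to compound 3 (0.98 log units; beyond the scatter). For compound 3 the expected value is 2000 nM, with an estimated range from 600 nM to 7000 nM.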

Compound 3, half-maximal inhibitory concentration: 1040 nM
Compound 3: the middle estimate sits 1.9-fold (0.28 log units) above what was measured; the measured number falls inside the stated range.
By their numbers in this assay, from the lowest: compounds 1 and 3 (each within the scatter of the next); then compound 2.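

In this assay the change to furan-2-yl gives an 18-fold lower number from compound 2 to compound 3 (1.26 log units; beyond the scatter) and so shows that the weak number of compound 2 is not shared by every replacement of the 1,3-thiazol-4-yl group at this position. The second comparison, a 1.2-fold higher number from compound 1 to compound 3 (0.07 log units; within the scatter), places the furan-2-yl and 1,3-thiazol-4-yl groups level in this assay. Going by these compounds alone, this change also removes the hydrogen-bond donor of the 1H-imidazol-2-yl group, although compound 2 is the only compound here that shows the weak number, so one compound cannot establish a link between the two.

No measurement here explains why the number moves at this position. As far as these compounds go, whether a phenyl ring, an amine or a carboxylic acid in this place would stay level with compounds 1 and 3 or fall back towards compound 2 remains open.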